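Ring stereocentre inversion from compound 3 to compound 4

The source may report more compounds than this note shows. Statements on the series, on what has been measured and on what is new or still open speak of the compounds shown alone.

Measured so far in an assay on HEK293 cells for inhibition of sialidase-3 (Homo sapiens), read by fluorescence, with a stated time of 1 h; a lower number here means a stronger inhibitor, a higher number a weaker inhibitor:
- compound 1 `CO[C@]1(C(=O)O)C=C[C@@H](NC(C)=O)[C@H]([C@H](O)[C@H](O)CO)O1`: compound 1 gives > 1000000 nM, a limit.
- compound 2 `CO[C@@]1(C(=O)O)C=C[C@@H](NC(C)=O)[C@H]([C@H](O)[C@H](O)CO)O1`: compound 2 gives > 1000000 nM, a limit.
- compound 3 `CCS[C@]1(C(=O)O)C=C[C@@H](NC(C)=O)[C@H]([C@H](O)[C@H](O)CO)O1`: compound 3 gives > 1000000 nM, a limit.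

Compound 3 stands only at a limit in this assay, as do the other two values, because of the limit of > 1000000 nM in this assay, at which 3 of the 3 values shown sit. Compound 4 `CCS[C@@]1(C(=O)O)C=C[C@@H](NC(C)=O)[C@H]([C@H](O)[C@H](O)CO)O1` is the next structure; the change is the two compounds have the same atoms and bonds and differ only in configuration as drawn: 1 of 5 stereo elements differ; a stereocentre at a saturated ring carbon is drawn S in compound 3 and R in compound 4. For the measured compounds named here, two measured steps bear on it: a step that the two limits leave unreadable from compound 1 to compound 2, a parallel inversion at the same kind of centre, and a step that the two limits leave unreadable from compound 1 to compound 3, the ethylsulfanyl entering. Both are unreadable, and compounds 1 and 2 show nothing by virtue of the fact that compounds 1 and 2 differ only in the configuration as drawn. No step beyond the scatter is therefore expected for a number no higher from compound 3 to compound 4 (the limit leaves the size open). Compound 4 is estimated at 1000000 nM, range 300000 nM to 5000000 nM, most likely reported again as a limit.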

Compound 4, half-maximal inhibitory concentration: > 1000000 nM
Compound 4 gave a limit, no number (the forecaster's own chance of this, stated with the estimate: 85%); the middle value sits exactly at the limit.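

No new step can be read in this assay: compound 4, like compound 2 and compound 3, stands only at a limit. The compounds shown leave open whether configuration or ethylsulfanyl in place of methoxy changes inhibition at all.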